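The source may report more compounds than this note shows. Statements on the series, on what has been measured and on what is new or still open speak of the compounds shown alone.

The series is built on a shared diaryl ether urea core. Compound 1 `O=C(Nc1ccccc1)Nc1ccc(Oc2ccc(-c3nccs3)cc2)cc1` carries the thiazole-bearing core and a plain phenyl on the urea; in a functional assay on A549 cells (Homo sapiens) for inhibition, read by MTT assay and WST assay, with a stated time of 72 h, tested at 10 uM (a lower number here means less inhibition of growth, a higher number more inhibition of growth at the concentration tested), compound 1 gives "not determined" (no result reported). In this assay compound 2 `O=C(Nc1ccc(Oc2ccc(-c3nccs3)cc2)cc1)Nc1cc(C(F)(F)F)ccc1Cl` gives 75.5%. Compound 3 `O=C(Nc1ccccc1)Nc1ccc(Oc2ccc(-c3ncc[nH]3)cc2)cc1`, with the imidazole-bearing core and a plain phenyl, gives 7.09% in this assay and so stands lowest of the two numbers, with the gap to compound 2 lying beyond the scatter.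

Compound 4 `O=C(Nc1ccc(Oc2ccc(-c3ncc[nH]3)cc2)cc1)Nc1ccc(F)c(Cl)c1` differs from compound 3 in one place: 3-chloro-4-fluorophenyl in place of phenyl on an amide-type nitrogen. Among the measured compounds shown here, no measured pair isolates this change, so the direction rests on the two values alone. A moderate rise in growth inhibition is expected, a number 22.9 percentage points higher from compound 3 to compound 4 (beyond the scatter), with compound 4 estimated at 30% within 5% to 65%.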

Compound 4, percent growth inhibition at one concentration: 14.6%
Estimate against measurement, compound 4: 15.4 percentage points above; measured number inside the range.
By their numbers in this assay, from the lowest: compounds 3 and 4 (each within the scatter of the next); then compound 2.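

In this assay, among the compounds shown here, 3-chloro-4-fluorophenyl in place of phenyl on an amide-type nitrogen gives a number 7.5 percentage points higher from compound 3 to compound 4 (within the scatter), the first measured step at this position. This swap therefore leaves the growth inhibition of the imidazole-bearing core within the scatter at the concentration tested. Nothing available here accounts for this result. As far as these compounds go, whether an amine or a carboxylic acid on the phenyl ring would give a different number remains open, and so does the effect of this change on the thiazole-bearing core of compound 1, which has no number.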